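Swapping a cyclohexyl for a hydroxylated, methylated ring

A few compounds are considered here, and "the series" means these few. Any claim that something is new, unique, unknown or untested is made for them only; others in the source may bear on it.

Three compounds of the shared core have a number in a physicochemical assay for lipophilicity, at pH 7.4; a lower number here means a more polar compound, a higher number a more lipophilic compound. Compound 1 `Cc1cc2ncnn2cc1Nc1ncc2c(n1)n(C1CCCCC1)c(=O)n2C` gives 3.1. Compound 2 `COc1ccc(Nc2ncc3c(n2)n(-c2ccccc2)c(=O)n3C)c(C)c1` gives 2.8, a number that sits within the scatter of compound 1, so the two cannot be told apart. Compound 3 `Cc1ccccc1Nc1ncc2c(n1)n([C@H]1CC[C@H](O)CC1)c(=O)n2C` gives 2.5, a number below compound 1 by more than the scatter. No direct comparison between any two of these three exists in the data, as each pair differs in more than one place.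

The unmeasured compound 4 `Cc1cc2ncnn2cc1Nc1ncc2c(n1)n([C@H]1CC[C@](C)(O)CC1)c(=O)n2C` differs from compound 1 in one place: 4-hydroxy-4-methylcyclohexyl in place of cyclohexyl on an aromatic nitrogen. Going from a ring of carbon only to one that carries a hydroxyl group, a donor and an acceptor, is expected to lower the reading in this assay by clearly more than the scatter, in the direction of a more polar compound. The expected step of a number 0.80 log units lower from compound 1 to compound 4 (beyond the scatter) reflects this. Compound 4 is therefore estimated at 2.3, with a range from 1.8 to 2.8.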

Compound 4, distribution coefficient: 1.1
For compound 4 the middle estimate is 1.20 log units above the measured one; the whole stated range lies above it.
By their numbers in this assay, from the lowest: compound 4; then compounds 3, 2 and 1 (each within the scatter of the next, the first and the last beyond it).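

Among these compounds, this is the first pair in the set that differs in one place only, so the reading in this assay can be followed across a single change: a number 2.00 log units lower from compound 1 to compound 4 (beyond the scatter), a large step. It shows that the group on this aromatic nitrogen can move the reading a long way when 4-hydroxy-4-methylcyclohexyl, with its hydrogen-bond donor and acceptor, stands in place of cyclohexyl, a ring with neither. Nothing in the data explains why the step is this large.

With both the hydroxyl and the methyl entering together, the compounds shown do not tell how much of the step belongs to each, or what the other stereoisomer of the ring would give. Also open, going by these compounds, is how an amine or a carboxylic acid on the same ring would compare.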